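The source may hold more compounds than are shown below. What is called first, only, known or untested is meant among the compounds shown, and "the series" means these compounds.

Measured so far in an ADME assay for pharmacokinetics, read by HPLC, in phosphate buffer, at 37 degrees C, at pH 7.4; a lower number here means that the compound disappears faster, a higher number that the compound lasts longer:

- compound 1, `CCOC(=O)OCC(CO)CCn1cnc2cnc(N)nc21`: compound 1 gives 168 h
- compound 2, `CCCCCOC(=O)OCC(CO)CCn1cnc2cnc(N)nc21`: compound 2 gives 168 h
- compound 3, `COC(=O)OCC(CO)CCn1cnc2cnc(N)nc21`: compound 3 gives 24 h

Compound 3 stands lowest of the three numbers in this assay. Its distance from the other two is the same in both cases: a 7.0-fold lower number from compound 1 to compound 3 (0.85 log units; beyond the scatter) and a 7.0-fold lower number from compound 2 to compound 3 (0.85 log units; beyond the scatter), each beyond the scatter, each a modest step. Compound 1 and compound 2 sit together, since no change at the digits printed from compound 1 to compound 2 (within the scatter).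

Compound 4 is `CC(C)COC(=O)OCC(CO)CCn1cnc2cnc(N)nc21`. It differs from compound 3 by a single change: isopropyl in place of hydrogen on a saturated chain carbon bound to an oxygen next to a carbonyl group. This is the mirror image of the two steps already known. Taking the methyl away from compound 1, or the butyl away from compound 2, lowered the half-life in this assay by the same modest amount, and lengthening the chain from compound 1 to compound 2 changed nothing within the scatter. Putting an isopropyl in at that same place on compound 3 is therefore expected to undo the drop, a step of about a 6.3-fold higher number from compound 3 to compound 4 (0.80 log units; beyond the scatter), upward.

Compound 4 is accordingly expected to give about 150 h in this assay, within a range of 60 h to 350 h.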

Compound 4, half-life: 408 h
Estimate against measurement, compound 4: 2.7-fold (0.43 log units) below, and the stated range ends below it.
By their numbers in this assay, from the lowest: compound 3; then compounds 1 and 2 (each within the scatter of the next); then compound 4.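

Among the compounds shown here, at the saturated chain carbon bound to an oxygen next to a carbonyl group, isopropyl in place of hydrogen does more than bring back what the earlier compounds suggested, as this assay gives a 17-fold higher number from compound 3 to compound 4 (1.23 log units; beyond the scatter) as a large step. The methyl of compound 1 and the butyl of compound 2 could not be told apart, which made the choice of group at this place look unimportant, but isopropyl stands apart from both, with a 2.4-fold higher number from compound 1 to compound 4 (0.39 log units; beyond the scatter) and a 2.4-fold higher number from compound 2 to compound 4 (0.39 log units; beyond the scatter) as modest steps beyond the scatter, so the isobutoxycarbonyl of compound 4 gives the longest half-life of the four and the kind of group matters here, not only whether one is present. Nothing at hand gives a reason for this.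

From the compounds shown here alone, the link to branching rests on compound 4 alone, so it stays open whether a second branched group such as tert-butyl or a ring such as cyclohexyl at this place would behave in the same way. Going by these compounds, it also stays open what a chain ending in an amine or a carboxylic acid would do at this place.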